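The source may hold more compounds than are shown below. What is called first, only, known or untested is meant among the compounds shown, and "the series" means these compounds.

Working notes on the series in a functional assay on the whole organism (strain Sprague-Dawley) for inhibition, with Rattus norvegicus as the target; a higher number here means that more compound is needed for the effect, a lower number that less compound is needed. Compound 1 `Fc1ccc2ncc(-c3nn[nH]n3)cc2c1` gives < 25 mg/kg in this assay, which is a limit of the assay rather than a number. Compound 2 `Fc1cccc2cc(-c3nn[nH]n3)cnc12` gives > 10 mg/kg in this assay, again a limit and not a number. Compound 3 `O=c1c(-c2nn[nH]n2)c[nH]c2c(Br)cccc12` gives > 5 mg/kg in this assay, likewise a limit and not a number. Within the data shown here, no two of the three compounds differ in a single place, so no measured step exists among them; all the three values show is that each sits at its own limit, as recorded in the limit of < 25 mg/kg in this assay, at which 1 of the 3 values shown sits, the limit of > 10 mg/kg in this assay, at which 1 of the 3 values shown sits, and (the limit of > 5 mg/kg in this assay, at which 1 of the 3 values shown sits). Compound 3 thus stands on a limit alone, with no number behind it.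

Compound 4 `O=c1c(-c2nn[nH]n2)c[nH]c2c(C(F)(F)F)cccc12` has not yet been measured in this assay. It differs from compound 3 by trifluoromethyl in place of bromo on an aromatic carbon. Among the measured compounds shown here, with no measured step to rest on, the expected step is a step that the limit leaves unreadable from compound 3 to compound 4, meaning no change beyond the scatter is expected in either direction. Compound 4 is expected to give about 10 mg/kg in this assay, with a range from 3 mg/kg to 30 mg/kg, and a limit rather than a number may again be all this assay reports.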

Compound 4, minimum effective dose: 0.156 mg/kg
For compound 4 the middle estimate is 64-fold (1.81 log units) above the measured one, and the stated range ends above it.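

In this assay, among these compounds, trifluoromethyl in place of bromo on an aromatic carbon, ortho to a fused ring, gives an at least 32-fold lower number from compound 3 to compound 4 (1.50 log units; beyond the scatter), the first measured step. Among the compounds shown here, compound 4 is also the first compound here with a number rather than a limit, which shows that this single change on the shared core can move the minimum effective dose well beyond the scatter. Compound 3 stands on a limit, so the step is a bound and not an exact gap: the limit of > 5 mg/kg in this assay, at which 1 of the 4 values shown sits.

The compounds shown leave open whether a methoxy group or a nitrile at this position would give a similar step. The exact size of the step and its cause also remain open, and steps from compound 1 or compound 2 cannot be read, as each differs from the others in more than one place.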